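The compounds below may be only part of what the source reports. "The series", "measured", "known", "first", "only" and "open" are said of these compounds alone.

Compound 1, `CCN1CCc2c(sc(N)c2C(N)=O)C1`, in a functional assay (strain AB) with Danio rerio as the target, read by microscopy, with a stated time of 1 h; a higher number here means that more compound is needed for the effect, a lower number that less compound is needed: > 25000 nM
Compound 2, `CCN1CCc2c(sc(NC(=O)Nc3ccc4ccccc4c3)c2C(N)=O)C1`: 1780 nM
Compound 3, `CC(C)CN1CCc2c(sc(NC(=O)Nc3ccc(Cl)cc3)c2C(N)=O)C1`: 4510 nM

All three share one core, carrying a different group on the ring nitrogen and, in compounds 2 and 3, a urea on the amino group. Compound 1, with no urea, gives only a limit of the assay, (the limit of > 25000 nM in this assay, at which 1 of the 3 values shown sits). Of the two real numbers, compound 3 stands higher: its value lies above that of compound 2 by more than the usual scatter.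

Compound 4, `CC(C)(C)OC(=O)CN1CCc2c(sc(NC(=O)Nc3ccc(Cl)cc3)c2C(N)=O)C1`, has not yet been measured in this assay. It differs from compound 3 in one place: tert-butoxycarbonyl in place of isopropyl on a saturated chain carbon bound to an amine nitrogen in a ring. For the measured compounds named here, no pair of measured compounds shows this kind of change, so nothing in the data sets its size. The expectation is a modest step, most likely toward a higher number, of a size close to the edge of the scatter. Compound 4 is therefore estimated at 6500 nM, with a range from 1800 nM to 24000 nM, meaning an expected step of a 1.4-fold higher number from compound 3 to compound 4 (0.16 log units; within the scatter).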

Compound 4, half-maximal effective concentration: > 25000 nM
Compound 4 ended at the assay's limit (the forecaster's own chance of this, stated with the estimate: 20%); middle value at least 3.8-fold (0.58 log units) away from the limit.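

Exchanging isobutyl for (tert-butoxycarbonyl)methyl, with the rest of the molecule unchanged, gives an at least 5.5-fold higher number from compound 3 to compound 4 (0.74 log units; beyond the scatter) in this assay, so this position does not accept every group without a change in the read-out. This is the only single-place change shown, and it sets a lower bound on what such a change can do here. Compound 4 gives > 25000 nM, which is a limit of the assay and not a number, so the step has no upper end: the limit of > 25000 nM in this assay, at which 2 of the 4 values shown sit.

The compounds shown do not separate the part played by the carbonyl from that of the tert-butyl end of the new group. From the compounds shown here alone, whether a carboxylic acid, a methyl ester or a simple amide on the same carbon would stay near compound 3 remains open.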